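Chain terminus variations on a shared pyrimidinol core

The source may report more compounds than this note shows. Statements on the series, on what has been measured and on what is new or still open speak of the compounds shown alone.

Measured so far in a functional assay (Homo sapiens), read by luminescence, with stated times of 12 h and 48 h; on this read-out lower numbers stand for an effect already at smaller amounts and higher numbers for an effect only at larger amounts of compound:
compound 1 `COc1nc(N(C)C)nc(CCCCCCCCCCO)c1O`: 345 nM
compound 2 `CCCCCCCCCCc1nc(N(C)C)nc(OC)c1O`: 68 nM

Compound 2 stands lowest of the two numbers; its nearest neighbour is compound 1, and the step of a 5.1-fold lower number from compound 1 to compound 2 (0.71 log units; beyond the scatter) lies beyond the scatter. That step is the only one measured and it concerns the end of the saturated chain: hydrogen in place of hydroxy on a saturated chain carbon, ten or more bonds along the chain from an aromatic carbon.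

Compound 3 `CCCCCCCCCCCCCCc1nc(N(C)C)nc(OC)c1O` is not yet measured. It differs from compound 2 by butyl in place of hydrogen on a saturated chain carbon, ten or more bonds along the chain from an aromatic carbon, that is, the chain is lengthened at its far end while the terminus stays a plain hydrogen-bearing carbon. The measured step from compound 1 to compound 2 touches the same region of the chain, but it swaps a hydroxy for hydrogen rather than lengthening the chain, so it gives no direct reading on the size of this change. Nothing measured speaks against or for a longer chain.

For compound 3 the expected step is a 1.2-fold lower number from compound 2 to compound 3 (0.09 log units; within the scatter), likely within the scatter. Compound 3 is therefore estimated at 55 nM in this assay, with a range of 15 nM to 220 nM.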

Compound 3, half-maximal effective concentration: 22 nM
Compound 3: the middle estimate sits 2.5-fold (0.40 log units) above what was measured, and the stated range covers the measured number.
By their numbers in this assay, from the lowest: compound 3; then compound 2; then compound 1.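

Working notes on the chain end, read in this assay: butyl in place of hydrogen on a saturated chain carbon, ten or more bonds along the chain from an aromatic carbon, gives a 3.1-fold lower number from compound 2 to compound 3 (0.49 log units; beyond the scatter) and so lies beyond the scatter, which shows that this position responds to lengthening of the chain as well as to the exchange of hydroxy for hydrogen. Going by these compounds alone, replacing hydroxy with butyl at the same place gives a 16-fold lower number from compound 1 to compound 3 (1.20 log units; beyond the scatter), a large step, and among the three compounds both changes at the chain end run toward lower numbers, with no compound going against that direction. No supporting measurement accompanies these compounds, so the data give no explanation for either step.

Still open, from the compounds shown here alone, is whether a chain longer than that of compound 3 would carry the trend further or reverse it, since a single lengthening cannot show where the trend ends. Also open, going by these compounds, is how a terminal amine, a carboxylic acid or a phenyl group would compare with the plain chain end of compound 3.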